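Swapping a dichlorophenyl for a bromophenyl on a GnRH antagonist

This account rests on a few compounds, and the source may have more. Where it says the series, first, only, none or still open, it means among the compounds named here.

Measured compounds:
Compound 1, `O=C(Nc1cc2c(OCCC3CCCCN3)c(-c3ccc(Cl)c(Cl)c3)c(O)nc2cc1Cl)NC1CC1`: 18 nM
Compound 2, `Cc1cc(C)cc(-c2c(O)nc3cc(Cl)c(NC(=O)Nc4cccnc4)cc3c2OCCC2CCCCN2)c1`: 20 nM

Both numbers come from a functional assay on cells (Pituitary gland cell) for antagonist activity at Gonadotropin-releasing hormone receptor (Rattus norvegicus); a higher number here means a weaker inhibitor, a lower number a stronger inhibitor. In this assay compound 1 gives 18 nM, the lowest of the two numbers shown; the nearest neighbour is compound 2, whose value in this assay is 20 nM, a difference that lies within the scatter, so the two cannot be told apart on these data.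

Compound 3, `O=C(Nc1cc2c(OCCC3CCCCN3)c(-c3cccc(Br)c3)c(O)nc2cc1Cl)NC1CC1`, has not yet been measured in this assay. It differs from compound 1 in one place: 3-bromophenyl in place of 3,4-dichlorophenyl on an aromatic carbon. In words, a 3-bromophenyl takes the place of a 3,4-dichlorophenyl on an aromatic carbon of the shared core. For the measured compounds named here, no step between two measured compounds covers such a change, so there is no measured guide to its size or direction.

Given that, the step from compound 1 to compound 3 is expected to be small, at most a modest weakening, as a 1.7-fold higher number from compound 1 to compound 3 (0.22 log units; within the scatter) states. Compound 3 is therefore estimated at 30 nM in this assay, with a range from 10 nM to 90 nM.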

Compound 3, half-maximal inhibitory concentration: 6 nM
Compound 3: the middle estimate sits 5.0-fold (0.70 log units) above what was measured; measured number outside the range, below it.
By their numbers in this assay, from the lowest: compound 3; then compounds 1 and 2 (each within the scatter of the next).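

In this assay, replacing the 3,4-dichlorophenyl with a 3-bromophenyl gives a 3.0-fold lower number from compound 1 to compound 3 (0.48 log units; beyond the scatter), a step beyond the scatter, so what this aromatic ring carries matters at this position, ortho to both the hydroxy group and the 2-(piperidin-2-yl)ethoxy group. The step also shows that the 3,4-dichlorophenyl is not needed for a low number here, yet it bundles two changes: one ring substituent is gone, and the remaining halogen is bromine rather than chlorine, so this single pair cannot show which change matters. No measurement at hand explains why the number drops.

A 3-chlorophenyl at this position would separate those two changes, while a 3-methoxyphenyl or a 3-aminophenyl would test whether a halogen on the ring is needed at all. Going by these compounds, compound 2 differs from compound 3 in more than one place, so whether the same change would give a similar step alongside its other urea group also remains open.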